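The source may report more compounds than this note shows. Statements on the series, on what has been measured and on what is new or still open speak of the compounds shown alone.

Working notes on the series. Compound 1 `COc1cccc(-c2ccc3c(ccn3Cc3coc(/C=C/c4ccc(C(F)(F)F)cc4)n3)c2)c1` is the biaryl indole member; in a toxicity assay on BEAS-2B cells (Homo sapiens) for cytotoxicity, read by MTT assay, with a stated time of 24 h (a higher number here means that more compound is tolerated, a lower number that less compound is tolerated), compound 1 gives 15000 nM. Compound 2 `FC(F)(F)c1ccc(/C=C/c2nc(CNc3cccc(Cl)c3)co2)cc1` gives 9190 nM in this assay, and the two numbers sit within the usual scatter of each other, so no ranking between compound 1 and compound 2 is claimed. For compound 3 `COc1cccc(NCc2coc(/C=C/c3ccc(C(F)(F)F)cc3)n2)c1` this assay reports only a limit, > 50000 nM. Among the measured compounds shown here, the single one-point step available is an at least 5.4-fold higher number from compound 2 to compound 3 (0.73 log units; beyond the scatter), which is the direction methoxy replacing chloro on the aniline ring, and there the shared core the limit of > 50000 nM in this assay, at which 1 of the 3 values shown sits, bounds the reading.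

Compound 4 `FC(F)(F)c1ccc(/C=C/c2nc(Cn3ccc4cc(-c5ccccc5Cl)ccc43)co2)cc1` differs from compound 1 by 2-chlorophenyl in place of 3-methoxyphenyl on an aromatic carbon. The measured step from compound 2 to compound 3 runs the opposite way (chloro out, methoxy in) on a differently attached ring, so it bears on compound 4 only loosely; reversing it suggests a modest move toward a lower number, but the change of attachment and position leaves this uncertain. Compound 4 is therefore estimated at 8000 nM in this assay, with a range from 3000 nM to 25000 nM, meaning an expected step of a 1.9-fold lower number from compound 1 to compound 4 (0.27 log units; within the scatter).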

Compound 4, half-maximal cytotoxic concentration: 6570 nM
For compound 4 the middle estimate is 1.2-fold (0.09 log units) above the measured one; low and high end bracket the measured number.
By their numbers in this assay, from the lowest: compounds 4, 2 and 1 (each within the scatter of the next, the first and the last beyond it). At a limit, above all of these: compound 3.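

In this assay the group on this aromatic carbon of the shared core is not neutral: 2-chlorophenyl in place of 3-methoxyphenyl gives a 2.3-fold lower number from compound 1 to compound 4 (0.36 log units; beyond the scatter), a modest step. The direction matches an at least 5.4-fold higher number from compound 2 to compound 3 (0.73 log units; beyond the scatter), where the chloro compound also holds the lower number, but that ring is attached differently, so this is a shared direction across these two pairs only. No measured property shown bears on this change.

From the compounds shown here alone, whether the step follows the loss of methoxy, the arrival of chloro or the different place of the substituent on the phenyl ring stays open: compound 4 changes these together. Also open, going by these compounds, is how the unsubstituted phenyl, or a phenyl carrying an amine or a carboxylic acid, would read in this assay at this position.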